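From Nitro to Methoxy: An Expected Shift for Compound 4

A few compounds are considered here, and "the series" means these few. Any claim that something is new, unique, unknown or untested is made for them only; others in the source may bear on it.

Three compounds have been measured in a functional assay on PC-3 cells (Homo sapiens) for antiproliferative activity, read by MTT assay, with a stated time of 48 h; on this read-out higher numbers stand for weaker inhibition and lower numbers for stronger inhibition:
Compound 1, `CS(=O)(=O)c1ccc(Nc2nccc(Nc3nc4ccc(F)cc4s3)n2)cc1`, gives 1940 nM.
Compound 3, `Cc1cnc(Nc2ccc(S(N)(=O)=O)cc2)nc1Nc1nc2ccc(Cl)cc2s1`, gives 5400 nM.
Compound 2, `Cc1cnc(Nc2ccc([N+](=O)[O-])cc2)nc1Nc1nc2ccccc2s1`, reaches only a limit of the assay, > 50000 nM.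

Compound 2 therefore has no number of its own in this assay; it sits at the limit (the limit of > 50000 nM in this assay, at which 1 of the 3 values shown sits), and all that can be said is that its inhibition is too weak to be resolved there. Compound 1 and compound 3 each carry a different group on the same aromatic ring and both give measurable values.

Compound 4, `COc1ccc(Nc2ncc(C)c(Nc3nc4ccccc4s3)n2)cc1`, has not yet been tested. It differs from compound 2 in one place: methoxy in place of nitro on an aromatic carbon. For the measured compounds named here, no measured pair shows this same change, so the size of the step is not known from the data. Since compound 2 starts at a limit, any measurable result for compound 4 would be a step toward stronger inhibition, and the step is expected to exceed the usual scatter, though by how much remains uncertain.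

The step from compound 2 to compound 4 in this assay is expected to be an at least 5.5-fold lower number from compound 2 to compound 4 (0.74 log units; beyond the scatter). Compound 4 is estimated at 9000 nM, with a likely range from 1500 nM to 50000 nM.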

Compound 4, half-maximal inhibitory concentration: > 50000 nM
Compound 4 ended at the assay's limit; the forecaster's own chance of this, stated with the estimate: 25%; at least 5.5-fold (0.74 log units) between middle value and limit.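

In this assay compound 4 gives > 50000 nM as a limit of the assay, not a number. For the compounds shown here, compound 2 sits at the same limit, so no step from compound 2 to compound 4 can be read: the limit of > 50000 nM in this assay, at which 2 of the 4 values shown sit. The compounds shown leave open whether methoxy in place of nitro changes inhibition at all.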